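Methylsulfanyl Moved From One Ring Position to Another

This account rests on a few compounds, and the source may have more. Where it says the series, first, only, none or still open, it means among the compounds named here.

Compound 1 `COc1ccc(NC(=O)N[C@H]2CC[C@H](Oc3ccc(F)cc3)CC2)cc1`: > 20000 nM
Compound 2 `CSc1ccccc1NC(=O)N[C@H]1CC[C@H](Oc2ccc(F)cc2)CC1`: > 20000 nM

Two ureas on a shared core have so far been tested in a functional assay on CRL2813 cells (Homo sapiens) for cytotoxicity, read by sulforhodamine B assay, with a stated time of 5 days; on this read-out lower numbers stand for stronger inhibition and higher numbers for weaker inhibition. Compound 1 `COc1ccc(NC(=O)N[C@H]2CC[C@H](Oc3ccc(F)cc3)CC2)cc1` returns only a limit of the assay, namely > 20000 nM. Compound 2 `CSc1ccccc1NC(=O)N[C@H]1CC[C@H](Oc2ccc(F)cc2)CC1` likewise returns only a limit of the assay, namely > 20000 nM. The step that the two limits leave unreadable from compound 1 to compound 2 cannot be read because of the limit of > 20000 nM in this assay, at which 2 of the 2 values shown sit. Compound 2 therefore stands at the limit, with no number of its own to place it.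

Compound 3 `CSc1cccc(NC(=O)N[C@H]2CC[C@H](Oc3ccc(F)cc3)CC2)c1` has not yet been measured. It differs from compound 2 by 3-(methylsulfanyl)phenyl in place of 2-(methylsulfanyl)phenyl on an amide-type nitrogen. Among the measured compounds shown here, the single measured step, the one with 2-(methylsulfanyl)phenyl replacing 4-methoxyphenyl, bears on the question of how the aromatic substituent matters, but it is unreadable, so neither size nor direction can be drawn from it. With both known compounds at the limit, compound 3 is expected to show a step of a number no higher from compound 2 to compound 3 (the limit leaves the size open) that amounts to nothing beyond the scatter, most probably another limit. Compound 3 is accordingly estimated at 20000 nM, within a range from 5000 nM to 60000 nM.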

Compound 3, half-maximal inhibitory concentration: 11100 nM
Estimate against measurement, compound 3: 1.8-fold (0.26 log units) above, within the range that was stated.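

In this assay, among the compounds shown here, compound 3 is the first compound here to return a number rather than a limit, although it carries the same atoms as compound 2, joined differently: 3-(methylsulfanyl)phenyl stands on the amide-type nitrogen in place of 2-(methylsulfanyl)phenyl. Moving the methylsulfanyl group gives an at least 1.8-fold lower number from compound 2 to compound 3 (0.25 log units; that floor lies within the scatter), and the exchange for 4-methoxyphenyl gives an at least 1.8-fold lower number from compound 1 to compound 3 (0.25 log units; that floor lies within the scatter). Both steps are floors rather than sizes, and neither floor lies beyond the scatter, so the series shows that compound 3 reaches a number in this assay but cannot fix how far it stands from the other two, because those two give only a limit: the limit of > 20000 nM in this assay, at which 2 of the 3 values shown sit.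

The compounds shown leave open whether the number of compound 3 depends on the sulfur atom of the methylsulfanyl group, or whether a methoxy group, a dimethylamino group or a carboxylic acid in its place on the same ring would also return a number. They also leave open whether the read-out of compound 3 would hold on any cell line other than this one.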